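Ethoxy to Ethyl on the Aromatic Ring: Expected Potency

The compounds below may be only part of what the source reports. "The series", "measured", "known", "first", "only" and "open" are said of these compounds alone.

compound 1 `COC(=O)C1=C(C)N=C(C)/C(=C(\O)OC)C1c1ccccc1OC` — in a functional assay (muscle tissue) with Cavia porcellus as the target (on this read-out lower numbers stand for an effect already at smaller amounts and higher numbers for an effect only at larger amounts of compound), compound 1 gives 57.5 nM
compound 2 `CCOc1ccccc1C1C(C(=O)OC)=C(C)N=C(C)/C1=C(\O)OC` — in this assay compound 2 gives 110 nM

For the measured compounds named here, compound 2 stands at the highest of the two numbers measured in this assay, but its only neighbour, compound 1, lies within the scatter of it: a 1.9-fold higher number from compound 1 to compound 2 (0.28 log units; within the scatter). Compound 3 `CCc1ccccc1C1C(C(=O)OC)=C(C)N=C(C)/C1=C(\O)OC` differs from compound 2 in one place: ethyl in place of ethoxy on an aromatic carbon. Going by the values given here, the single measured step that bears on this change also alters the group on this aromatic carbon, from compound 1 to compound 2, and it stayed within the scatter. Nothing measured shows what removing the oxygen of the ethoxy group does. The expectation is therefore a step from compound 2 to compound 3 of about a 1.2-fold higher number from compound 2 to compound 3 (0.07 log units; within the scatter), not beyond the scatter, with a wide band of uncertainty. Compound 3 is estimated at 130 nM in this assay, between 40 nM and 420 nM.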

Compound 3, half-maximal effective concentration: 6.46 nM
For compound 3 the middle estimate is 20-fold (1.30 log units) above the measured one; measured number outside the range, below it.
By their numbers in this assay, from the lowest: compound 3; then compounds 1 and 2 (each within the scatter of the next).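

Replacing the ring oxygen group with a plain carbon chain on this aromatic carbon matters far more in this assay than extending that chain did: ethyl in place of ethoxy gives a step beyond the scatter (a 17-fold lower number from compound 2 to compound 3 (1.23 log units; beyond the scatter)), whereas the earlier change from methoxy to ethoxy stayed within it (a 1.9-fold higher number from compound 1 to compound 2 (0.28 log units; within the scatter)). The same direction appears when ethyl replaces methoxy (an 8.9-fold lower number from compound 1 to compound 3 (0.95 log units; beyond the scatter)), so among these compounds, ethyl gives the lowest number against both oxygen-linked groups. No data given here bear on the reason for this shift.

As far as these compounds go, it remains open whether a shorter or longer carbon chain, such as methyl or propyl, would hold the low number seen with ethyl. Also open, from the compounds shown here alone, is how an amine or a hydroxyl group would read out on this same carbon.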